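A few compounds are considered here, and "the series" means these few. Any claim that something is new, unique, unknown or untested is made for them only; others in the source may bear on it.

Measured so far:
Compound 1 `Cc1ncn(CC(=O)N2CC(Oc3cc(C)n(C4CC4)c(=O)c3)C2)c(=O)c1C`: > 50000 nM (a limit)
Compound 2 `O=C(c1ccco1)N1CCN(Cc2cc(=O)c(OCc3ccccc3F)co2)CC1`: 2100 nM

Both compounds were tested in a functional assay on MIA PaCa-2 cells (Homo sapiens) for antiproliferative activity, read by MTT assay, with a stated time of 72 h (on this read-out higher numbers stand for weaker inhibition and lower numbers for stronger inhibition), on the same terms. For compound 1, the reading of > 50000 nM is a limit of the assay and not a number. Among the compounds with values here, compound 2, at 2100 nM, therefore holds the only true number so far, and it is the one reference point for what follows.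

Compound 3 `O=C(c1ccco1)N1CCN(Cc2cc(=O)c(OCc3c(F)cccc3Cl)co2)CC1` is still to be measured. It keeps the whole of compound 2 except for one place on the aromatic ring: chloro in place of hydrogen on an aromatic carbon. In words, chloro takes the place of hydrogen on an aromatic carbon, turning 2-fluorobenzyl into 2-chloro-6-fluorobenzyl.

Within the data shown here, no measured pair here shows what a change of this kind does, so the expectation is only a cautious one. A small shift towards stronger inhibition is expected, or none beyond the usual scatter. The expected step of a 1.4-fold lower number from compound 2 to compound 3 (0.15 log units; within the scatter) is therefore modest. The estimate for compound 3 is 1500 nM, with an expected range from 500 nM to 4500 nM in this assay.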

Compound 3, half-maximal inhibitory concentration: > 50000 nM
Compound 3 was reported as a limit (the forecaster's own chance of this, stated with the estimate: 4%); at least 33-fold (1.52 log units) between middle value and limit.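

In this assay, this carbon of the aromatic ring proves far from indifferent to substitution: chloro in place of hydrogen, a change of one heavy atom, gives an at least 23-fold higher number from compound 2 to compound 3 (1.37 log units; beyond the scatter), a large step beyond the usual scatter. Compound 3 reads > 50000 nM, which is a limit of the assay and not a number, so the step gives only a lower bound on the real difference. This is the first pair shown that differs in one place, and it reveals that the activity of compound 2 does not survive the move from 2-fluorobenzyl to 2-chloro-6-fluorobenzyl, which leaves compound 2 as the only compound with a true number: the limit of > 50000 nM in this assay, at which 2 of the 3 values shown sit.

The compounds shown leave open whether this loss belongs to chloro itself or would follow any group on this carbon, such as a methyl, a methoxy, a bromo or a second fluoro. They also do not tell whether chloro on another carbon of the ring, or a 2-chlorobenzyl group without the fluoro, would give the same result, and they offer no cause for the step.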